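Replacing 3-Chlorophenyl with 4-Methylpyridin-3-yl

This account rests on a few compounds, and the source may have more. Where it says the series, first, only, none or still open, it means among the compounds named here.

Compound 1 `CC/C(=C(/c1ccc(/C=C/C(=O)O)cc1)c1ccc(NS(C)(=O)=O)cc1)c1ccccc1`: 2310 nM in a functional assay on MCF7 cells (Homo sapiens) for cytotoxicity, read by CellTiter-Glo, with a stated time of 5 days; a lower number here means a stronger inhibitor, a higher number a weaker inhibitor
Compound 2 `CC/C(=C(/c1ccc(/C=C/C(=O)O)c(OC)c1)c1ccc2[nH]ncc2c1)c1ccccc1`: 31 nM in this assay
Compound 3 `CC/C(=C(/c1ccc(/C=C/C(=O)O)cc1)c1ccc2[nH]ncc2c1)c1cccc(Cl)c1`: 12 nM in this assay

Among these three, compound 3 has the lowest number and so the strongest inhibition: compound 2 sits above it by more than the usual scatter, and compound 1 sits far above it. Compound 4 `CC/C(=C(/c1ccc(/C=C/C(=O)O)cc1)c1ccc2[nH]ncc2c1)c1cnccc1C` has not yet been measured. It differs from compound 3 in one place: 4-methylpyridin-3-yl in place of 3-chlorophenyl on a double-bonded chain carbon bound to a double-bonded chain carbon and a saturated chain carbon. Going by the values given here, no measured pair shows this exact change, so the size of the step in this assay is uncertain. Among the compounds with values here, a modest weakening is expected, since compound 3 already stands at 12 nM and the change touches only one ring. Compound 4 is therefore estimated at 40 nM in this assay, within 12 nM to 150 nM, which means an expected step of a 3.3-fold higher number from compound 3 to compound 4 (0.52 log units; beyond the scatter).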

Compound 4, half-maximal inhibitory concentration: 150 nM
Compound 4: the middle estimate sits 3.8-fold (0.57 log units) below what was measured; the range from low to high includes it.
By their numbers in this assay, from the lowest: compound 3; then compound 2; then compound 4; then compound 1.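

Going by these compounds alone, this position tolerates less change than the earlier compounds could show: in this assay, 4-methylpyridin-3-yl in place of 3-chlorophenyl brings a 13-fold higher number from compound 3 to compound 4 (1.10 log units; beyond the scatter), although both groups have the same number of heavy atoms. So the choice of ring on this carbon can strongly shift the number. No measurement shown accounts for this step.

The change swaps several features at once, leaving open whether the ring nitrogen, the methyl or the lost chlorine matters most. A plain pyridin-3-yl or a 3-methylphenyl group at this place could separate them.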